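Chloro in place of fluoro: what to expect

The source may hold more compounds than are shown below. What is called first, only, known or untested is meant among the compounds shown, and "the series" means these compounds.

Compound 1 `Cc1ccc(/C=C2\CN(Cc3cn(Cc4cccc(Cl)c4)nn3)C/C(=C\c3ccc(C)cc3)C2=O)cc1`: 73500 nM
Compound 2 `Cc1ccc(/C=C2\CN(Cc3cn(Cc4ccccc4F)nn3)C/C(=C\c3ccc(C)cc3)C2=O)cc1`: > 100000 nM

In an ADME assay on HEK293 cells (Homo sapiens) for cytotoxicity, read by MTT assay, with a stated time of 24 h (on this read-out lower numbers stand for stronger inhibition and higher numbers for weaker inhibition), compound 2 stands at > 100000 nM as a limit of the assay, not a number. Compound 3 `Cc1ccc(/C=C2\CN(Cc3cn(Cc4ccccc4Cl)nn3)C/C(=C\c3ccc(C)cc3)C2=O)cc1` has chloro in place of fluoro on an aromatic carbon and so carries 2-chlorobenzyl instead of 2-fluorobenzyl. Within the data shown here, the one measured step is an at least 1.3-fold higher number from compound 1 to compound 2 (0.13 log units; that floor lies within the scatter) and runs from 3-chlorophenyl to 2-fluorophenyl, so it bears on this change only loosely. Among the measured compounds shown here, with compound 1 at 73500 nM as the only chloro value, a slightly lower number is expected in this assay and nothing clearly beyond the scatter. The expected step is an at least 1.1-fold lower number from compound 2 to compound 3 (0.04 log units; that floor lies within the scatter) in size. For compound 3 the estimated value is 90000 nM (range 45000 nM to 150000 nM).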

Compound 3, half-maximal inhibitory concentration: 91500 nM
Estimate against measurement, compound 3: 1.0-fold (0.01 log units) below, and the stated range covers the measured number.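

In this assay, chloro in place of fluoro on the benzyl group gives an at least 1.0-fold lower number from compound 2 to compound 3 (0.03 log units; that floor lies within the scatter), so this swap shows no clear change. With chloro kept, going from 3-chlorophenyl to 2-chlorophenyl gives a 1.2-fold higher number from compound 1 to compound 3 (0.10 log units; within the scatter), so this shift also stays within the usual spread of repeat measurements. Compound 2 is held at a limit of the assay, not a number: the limit of > 100000 nM in this assay, at which 1 of the 3 values shown sits.

The compounds shown leave open whether a different group on this ring, such as methoxy or an amine, would move the number beyond that spread.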